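The source may report more compounds than this note shows. Statements on the series, on what has been measured and on what is new or still open speak of the compounds shown alone.

Measured so far in a physicochemical assay for solubility, read by LC-MS, in phosphate buffer, measured as thermodynamic solubility, with a stated time of 24 h, at pH 7.4; on this read-out lower numbers stand for lower solubility and higher numbers for higher solubility:
Compound 1 `Cn1cc(-c2cnc3[nH]cc(-c4cncc(C#N)c4)c3c2)cn1` gives 17000 nM.
Compound 2 `Cn1cc(-c2cnc3[nH]cc(C4CCCNC4)c3c2)cn1` gives 1000000 nM.
Compound 3 `Cc1nn(C)cc1-c1cnc2[nH]cc(-c3cccc(C#N)c3)c2c1` gives 2000 nM.

Among these three, compound 3 stands lowest in this assay. Its nearest neighbour is compound 1, which sits clearly higher, beyond the usual scatter, while compound 2 sits far higher still, also well beyond the scatter.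

Compound 4 `Cn1cc(Nc2cnc3[nH]cc(-c4cccc(C#N)c4)c3c2)cn1` has not been measured yet. It differs from compound 3 in a single place: (1-methyl-1H-pyrazol-4-yl)amino in place of 1,3-dimethyl-1H-pyrazol-4-yl on an aromatic carbon. No measured pair in this set shows what such a swap does, so there is no shown step to lean on; the expectation rests only on the structural change and on where compound 3 sits. A modest rise in this assay is expected, beyond the scatter but well short of the level of compound 2. For compound 4 the expected value in this assay is 6000 nM, with a likely range from 1500 nM to 25000 nM. That expectation amounts to a step of a 3.0-fold higher number from compound 3 to compound 4 (0.48 log units; beyond the scatter).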

Compound 4, solubility: 31000 nM
Compound 4: middle estimate off by 5.2-fold (0.71 log units), on the low side; measured number outside the range, above it.
By their numbers in this assay, from the lowest: compound 3; then compounds 1 and 4 (each within the scatter of the next); then compound 2.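

Swapping 1,3-dimethyl-1H-pyrazol-4-yl for (1-methyl-1H-pyrazol-4-yl)amino on this aromatic carbon gives, in this assay, a 16-fold higher number from compound 3 to compound 4 (1.19 log units; beyond the scatter), the first change at a single place in this set, and it shows that the read-out responds strongly to what sits at this position. The two groups have the same number of heavy atoms, so the large step comes without any change in that count, although the entering group has a hydrogen-bond donor that the leaving group lacks. No measurement here explains the size of this step.

As far as these compounds go, the swap removes a ring methyl and adds an amino link at once, so the share of each remains open. A directly attached 1-methyl-1H-pyrazol-4-yl group, or an ether oxygen in place of the amino link, on the rest of compound 3 would bear on that question.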